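Piperidine in place of dimethylamine on a coumarin-like chain

The source may report more compounds than this note shows. Statements on the series, on what has been measured and on what is new or still open speak of the compounds shown alone.

Compound 1 `O=C(CCN1CCCCC1)c1cc2ccc(O)cc2oc1=O`: > 200000 nM
Compound 2 `COc1ccc2cc(C(=O)CCN(C)C)c(=O)oc2c1`: 7630 nM

Of the compounds shown here, two have been tested in an assay on cells for inhibition of Amine oxidase [flavin-containing] A (Homo sapiens), read by fluorescence, spectrophotometry and Amplex Red, with stated times of 60 min and 30 min; a lower number here means a stronger inhibitor, a higher number a weaker inhibitor. Compound 1 gives only > 200000 nM, which is a limit of the assay rather than a number. For the measured compounds named here, compound 2 gives 7630 nM in this assay, the only actual number so far. The other value, that of compound 1, sits at the limit (the limit of > 200000 nM in this assay, at which 1 of the 2 values shown sits). Going by the values given here, compound 2 and compound 1 differ in two places at once, so their two values show only that one reaches a number and the other does not.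

Compound 3 `COc1ccc2cc(C(=O)CCN3CCCCC3)c(=O)oc2c1` has not yet been measured. It differs from compound 2 by one change: piperidin-1-yl in place of dimethylamino on a saturated chain carbon, two bonds along the chain from a carbonyl carbon. Among the compounds with values here, no step between two measured compounds of this kind is available, so the expected effect rests on general experience rather than on these data. Such a change is expected to move the result only modestly, likely within the usual scatter, with no firm direction. For compound 3 the expected result is 10000 nM, between 2500 nM and 40000 nM. The step this estimate means, a 1.3-fold higher number from compound 2 to compound 3 (0.12 log units; within the scatter), is expected to be small.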

Compound 3, half-maximal inhibitory concentration: 12200 nM
Compound 3: the middle estimate sits 1.2-fold (0.09 log units) below what was measured, within the range that was stated.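

In this assay, piperidin-1-yl in place of dimethylamino on a saturated chain carbon, two bonds along the chain from a carbonyl carbon, gives a 1.6-fold higher number from compound 2 to compound 3 (0.20 log units; within the scatter), so the ring and the open amine cannot be told apart at this position. For the compounds shown here, the same compound also allows the first comparison that differs in only one place on the oxygen on the aromatic ring: methyl in place of hydrogen there goes with an at least 16-fold lower number from compound 1 to compound 3 (1.21 log units; beyond the scatter), which places the large step at that oxygen and not at the amine. Compound 1 gives a limit of the assay and not a number, so the true size of that step stays unknown, with only its least possible size printed: the limit of > 200000 nM in this assay, at which 1 of the 3 values shown sits.

On these data alone, it remains open whether other amines on the chain, such as morpholine or pyrrolidine, or a longer chain between the carbonyl and the nitrogen, would also leave the result within the scatter. As far as these compounds go, it is equally open how an ethyl or a benzyl group on the aromatic oxygen would compare with methyl.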